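The compounds below may be only part of what the source reports. "The series", "measured", "known", "first", "only" and "open" are said of these compounds alone.

Three compounds of one shared core were examined in an ADME assay on HepG2 cells (Homo sapiens) for cytotoxicity, read by luminescence, with a stated time of 72 h; on this read-out higher numbers stand for an effect only at larger amounts of compound and lower numbers for an effect already at smaller amounts. Compound 1 `CCOC(=O)c1c(-c2cccc(-c3ccccc3)c2)[nH]c2cc(OC)ccc2c1=O` gives in this assay only a limit, > 21500 nM, and not a number. Compound 2 `CCOC(=O)c1c(-c2cccc(OC)c2)[nH]c2cc(OC)ccc2c1=O` likewise reaches only the limit > 21500 nM. Compound 3 `CCOC(=O)c1c(-c2cccc(OC(C)C)c2)[nH]c2cc(OC)ccc2c1=O` also stops at the limit > 21500 nM. The cores of compound 2 and compound 1 differ by phenyl in place of methoxy on an aromatic carbon. From compound 2 to compound 3 the change is isopropyl in place of methyl on an oxygen on an aromatic ring, and the step is a step that the two limits leave unreadable from compound 2 to compound 3, because every value sits at the limit of > 21500 nM in this assay, at which 3 of the 3 values shown sit. The steps a step that the two limits leave unreadable from compound 1 to compound 2 and a step that the two limits leave unreadable from compound 1 to compound 3 are equally unreadable for the same reason, (the limit of > 21500 nM in this assay, at which 3 of the 3 values shown sit). Compound 4 `CCOC(=O)c1c(-c2cccc(-c3ccccc3)c2)[nH]c2cc(OC(C)C)ccc2c1=O` has not yet been measured; it differs from compound 1 by isopropyl in place of methyl on an oxygen on an aromatic ring, the same change as that from compound 2 to compound 3, at a place whose surroundings read the same. In this assay compound 4 is expected to give about 30000 nM, between 15000 nM and 100000 nM. The expected step from compound 1 to compound 4 is a step that the limit leaves unreadable from compound 1 to compound 4, which rests on all three measured compounds sitting at the limit of > 21500 nM in this assay, at which 3 of the 3 values shown sit.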

Compound 4, half-maximal effective concentration: > 21500 nM
Compound 4 gave a limit, no number (the forecaster's own chance of this, stated with the estimate: 85%); the middle value lies beyond the limit too.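

No new step can be read from compound 1 to compound 4 in this assay, because the values of both compounds are limits and not numbers: the limit of > 21500 nM in this assay, at which 4 of the 4 values shown sit. The compounds shown leave open at what concentration any of them would reach a half-maximal effect, and whether isopropoxy in place of methoxy changes that concentration at all.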